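Methyl for methoxy on the aryl ether of compound 3

This account rests on a few compounds, and the source may have more. Where it says the series, first, only, none or still open, it means among the compounds named here.

Measured in a functional assay for inhibition, with Homo sapiens as the target; a higher number here means weaker binding, a lower number tighter binding:
Compound 1 (`O=C(O)CC/C=C\CC1COC(c2ccco2)OC1c1cccnc1`) gives 1260 nM
Compound 2 (`CSc1ccc(OC(C)(C)C2OCC(C/C=C\CCC(=O)O)C(c3cccnc3)O2)c([N+](=O)[O-])c1`) gives 4.47 nM
Compound 3 (`COc1ccc(OC(C)(C)C2OCC(C/C=C\CCC(=O)O)C(c3cccnc3)O2)cc1`) gives 302 nM

Compound 3 (302 nM) holds the middle of the three numbers, with compound 1 (1260 nM) higher and compound 2 (4.47 nM) lower. Compound 4 (`Cc1ccc(OC(C)(C)C2OCC(C/C=C\CCC(=O)O)C(c3cccnc3)O2)cc1`) has methyl in place of methoxy on an aromatic carbon, para to a large group (methyl in place of methoxy on an aromatic carbon). Among the measured compounds shown here, only one measured step touches this aromatic ring: a 68-fold higher number from compound 2 to compound 3 (1.83 log units; beyond the scatter). That step exchanged far more atoms than this one does, so it offers only a loose guide. The expected step is therefore none beyond the scatter in this assay (a 1.2-fold lower number from compound 3 to compound 4 (0.07 log units; within the scatter)). Compound 4 is estimated at 260 nM with an expected range of 90 nM to 750 nM in this measurement.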

Compound 4, dissociation constant: 631 nM
For compound 4 the middle estimate is 2.4-fold (0.39 log units) below the measured one; low and high end bracket the measured number.
By their numbers in this assay, from the lowest: compound 2; then compound 3; then compounds 4 and 1 (each within the scatter of the next).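

In this assay, the change from 4-methoxyphenyl to 4-methylphenyl isolates a single group on this aromatic carbon, and a 2.1-fold higher number from compound 3 to compound 4 (0.32 log units; beyond the scatter) is a modest move beyond the scatter. Replacing the whole aryl group gives a far larger change, a 140-fold higher number from compound 2 to compound 4 (2.15 log units; beyond the scatter), so this one exchange accounts for only a small share of the range seen across these aryl ethers. No measurement given here explains the direction of the step. On these data alone, whether chloro or amino at this carbon would lower the number remains open. So does whether the nitro or the methylthio group of compound 2 matters more to its low number.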